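This account rests on a few compounds, and the source may have more. Where it says the series, first, only, none or still open, it means among the compounds named here.

Compound 1 `Cc1cn([C@@H]2C[C@H](O)[C@@H](CNC(=O)Nc3ccc(Br)cc3)O2)c(=O)[nH]c1=O` is one of three compounds that have been tested in an ADME assay on MRC5 cells (Homo sapiens) for cytotoxicity; on this read-out lower numbers stand for higher toxicity in this test and higher numbers for lower toxicity in this test. In this assay compound 1 gives > 50000 nM, which is a limit of the assay rather than a measured number. Compound 2 `Cc1cn([C@@H]2C[C@H](O)[C@@H](CNC(=S)Nc3ccc(Cl)c(C(F)(F)F)c3)O2)c(=O)[nH]c1=O` gives > 50000 nM in this assay, again a limit. Compound 3 `Cc1cn([C@@H]2C[C@H](O)[C@@H](CNC(=O)Nc3ccc(Cl)c(C(F)(F)F)c3)O2)c(=O)[nH]c1=O` gives > 50000 nM in this assay, also a limit. Compound 1 therefore stands where every measured compound stands: at the limit of > 50000 nM in this assay, at which 3 of the 3 values shown sit, with no numbered value that sets any one of the three apart from the others.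

Compound 4 `Cc1cn([C@@H]2C[C@H](O)[C@@H](CNC(=O)Nc3ccc(OC4CCOCC4)cc3)O2)c(=O)[nH]c1=O` has not yet been measured. It differs from compound 1 in a single place: (oxan-4-yl)oxy in place of bromo on an aromatic carbon. For the measured compounds named here, no step between two measured compounds is available to show what such a change does in this assay, since every measured compound sits at the same limit and the differences between them cannot be sized.

On that basis the expected step of a number no higher from compound 1 to compound 4 (the limit leaves the size open) is none beyond the scatter, and the most likely outcome is that compound 4 also comes back as a limit rather than a number. Compound 4 is estimated at 50000 nM in this assay, within a range from 20000 nM to 100000 nM.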

Compound 4, half-maximal cytotoxic concentration: > 50000 nM
Compound 4 ended at the assay's limit; the forecaster's own chance of this, stated with the estimate: 85%; the middle value lies on the limit itself.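

Compound 4 sits at the same limit as compound 1, so the step from bromo to (oxan-4-yl)oxy cannot be read in this assay: the limit of > 50000 nM in this assay, at which 4 of the 4 values shown sit.

The compounds shown leave open how far apart compound 1 and compound 4 really lie, and which change to the shared core, if any, would give a numbered value instead of a limit.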